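Trading a Bromo for a Phenyl in Compound 3

This account rests on a few compounds, and the source may have more. Where it says the series, first, only, none or still open, it means among the compounds named here.

Compound 1, `N=C(N)Nc1cccc(C(=O)NNC(=O)CC(CC(=O)O)c2ccc(-c3ccccc3)cc2)c1`: 2.8
Compound 2, `O=C(O)CC(CC(=O)NNC(=O)CCCCNc1ccccn1)c1ccc(Br)cc1`: 2.9

In a physicochemical assay for lipophilicity (a higher number here means a more lipophilic compound, a lower number a more polar compound), compound 2 gives 2.9, and compound 1 gives 2.8; the two values lie within the scatter of each other, so neither can be called more lipophilic. Compound 3, `O=C(O)CC(CC(=O)NNC(=O)CCCCNc1ccccn1)c1ccc(-c2ccccc2)cc1`, differs from compound 2 in one place: phenyl in place of bromo on an aromatic carbon. Within the data shown here, no measured pair shows this change here, so the expected step rests on the structural change alone; a rise beyond the scatter is expected, with a number 0.90 log units higher from compound 2 to compound 3 (beyond the scatter) as the estimated step. Compound 3 is expected to give 3.8, with a range from 3.2 to 4.4.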

Compound 3, partition coefficient: 3.74
For compound 3 the middle estimate is 0.06 log units above the measured one; measured number inside the range.
By their numbers in this assay, from the lowest: compounds 1 and 2 (each within the scatter of the next); then compound 3.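

Phenyl in place of bromo on an aromatic carbon, para to a large group, shifts the reading in this assay, with a number 0.84 log units higher from compound 2 to compound 3 (beyond the scatter). Compounds 1 and 2 differ in two places, so neither change could be read from them, but compound 3 separates them: a group of 11 heavy atoms in place of a group of 10 heavy atoms on a carbonyl carbon gives a number 0.94 log units higher from compound 1 to compound 3 (beyond the scatter). Nothing here gives a cause for either step.

As far as these compounds go, how an amine or a carboxylic acid would read at the bromo position remains open. So does whether the phenyl step would hold on the core of compound 1.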